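A few compounds are considered here, and "the series" means these few. Any claim that something is new, unique, unknown or untested is made for them only; others in the source may bear on it.

Compound 1 `COc1ccc2c(OCCn3c(=O)oc4ccc(C)cc43)ccnc2c1`, compound 2 `COc1ccc2c(OCCn3c(=O)oc4ccc(F)cc43)ccnc2c1` and compound 3 `COC(=O)c1ccc2oc(=O)n(CCOc3ccnc4cc(OC)ccc34)c2c1` share one core and differ only in the group carried on an aromatic carbon. In a functional assay on EBC-1 cells (Homo sapiens) for inhibition, read by sulforhodamine B assay, with a stated time of 72 h (on this read-out lower numbers stand for stronger inhibition and higher numbers for weaker inhibition), compound 1 gives only a limit, > 500 nM. Compound 2 likewise gives only a limit, > 500 nM. Compound 3 also gives only a limit, > 500 nM, so its standing on these numbers is not readable. The steps a step that the two limits leave unreadable from compound 1 to compound 2, a step that the two limits leave unreadable from compound 1 to compound 3 and a step that the two limits leave unreadable from compound 2 to compound 3 are all unreadable in size because of the limit of > 500 nM in this assay, at which 3 of the 3 values shown sit. Compound 4 `COc1ccc2c(OCCn3c(=O)oc4ccc(-c5cnn(C)c5)cc43)ccnc2c1` arises from compound 3 by the change (1-methyl-1H-pyrazol-4-yl in place of methoxycarbonyl on an aromatic carbon). Among the measured compounds shown here, none of the measured steps bears on this change in a readable way, so no direction can be drawn from them. Compound 4 is therefore expected, with wide uncertainty, at 300 nM (range 30 nM to 3000 nM), an estimated step of an at least 1.6-fold lower number from compound 3 to compound 4 (0.22 log units; that floor lies within the scatter).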

Compound 4, half-maximal inhibitory concentration: > 500 nM
Compound 4 ended at the assay's limit; the forecaster's own chance of this, stated with the estimate: 45%; middle value at least 1.6-fold (0.22 log units) from the limit.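

Among the compounds shown here, no step from compound 1, compound 2 or compound 3 to compound 4 can be read in size, because all four compounds sit at one limit: the limit of > 500 nM in this assay, at which 4 of the 4 values shown sit. The compounds shown leave open whether the methyl, fluoro, methoxycarbonyl and 1-methyl-1H-pyrazol-4-yl groups differ at all in inhibition.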